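Swapping a piperidine for a piperazine on the basic side chain

The compounds below may be only part of what the source reports. "The series", "measured", "known", "first", "only" and "open" are said of these compounds alone.

Measured compounds in a functional assay on HT-29 cells (Homo sapiens) for inhibition, read by MTT assay, with a stated time of 72 h; on this read-out lower numbers stand for stronger inhibition and higher numbers for weaker inhibition:
compound 1 `COc1cc2c(Oc3ccc(NC(=O)c4nn(-c5ccccc5)c(=O)cc4C)cc3F)ccnc2cc1OCCCN1CCN(C)CC1` gives 270 nM
compound 2 `COc1ccc(-n2nc(C(=O)Nc3ccc(Oc4ccnc5cc(OCCCN6CCCCC6)c(OC)cc45)c(F)c3)c(C)cc2=O)cc1` gives 3200 nM
compound 3 `COc1ccc(-n2nc(C(=O)Nc3ccc(Oc4ccnc5cc(OCCCN6CCC(C)CC6)c(OC)cc45)c(F)c3)c(C)cc2=O)cc1` gives 5450 nM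

Compound 3 has the highest number of the three; compound 2 is nearest, and the measured step of a 1.7-fold higher number from compound 2 to compound 3 (0.23 log units; within the scatter) is within the scatter, while compound 1 lies furthest away. Compound 4 `COc1ccc(-n2nc(C(=O)Nc3ccc(Oc4ccnc5cc(OCCCN6CCN(C)CC6)c(OC)cc45)c(F)c3)c(C)cc2=O)cc1` differs from compound 3 by 4-methylpiperazin-1-yl in place of 4-methylpiperidin-1-yl on a saturated chain carbon, three bonds along the chain from an oxygen on an aromatic ring. Within the data shown here, no measured step shows this exchange directly. Compound 1 also carries the 4-methylpiperazin-1-yl chain and gives 270 nM, but it differs from compound 4 elsewhere as well, so the two values alone give only a loose guide. The step of a 4.5-fold lower number from compound 3 to compound 4 (0.66 log units; beyond the scatter) is therefore expected to be a moderate lowering of the number. Compound 4 is estimated at 1200 nM, with a range from 300 nM to 4500 nM.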

Compound 4, half-maximal inhibitory concentration: 3520 nM
Compound 4: the middle estimate sits 2.9-fold (0.47 log units) below what was measured; the range from low to high includes it.
By their numbers in this assay, from the lowest: compound 1; then compounds 2, 4 and 3 (each within the scatter of the next).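

In this assay the exchange of 4-methylpiperidin-1-yl for 4-methylpiperazin-1-yl on this chain gives a 1.5-fold lower number from compound 3 to compound 4 (0.19 log units; within the scatter) and the exchange of piperidin-1-yl for the same group gives a 1.1-fold higher number from compound 2 to compound 4 (0.04 log units; within the scatter) so these three chain ends are not told apart here. Among these compounds, the large gap instead follows methoxy in place of hydrogen on an aromatic carbon, with a 13-fold higher number from compound 1 to compound 4 (1.12 log units; beyond the scatter) as the only step of the three beyond the scatter. Nothing measured here accounts for either finding.
As far as these compounds go, whether a morpholine or a dimethylamino group at the chain end would also leave the number unchanged stays open. So does whether a chlorine in place of that methoxy would carry the same large step.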